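The compounds below may be only part of what the source reports. "The series", "measured", "known", "first", "only" and "open" are said of these compounds alone.

Two compounds that share one core have so far been examined in a functional assay on A549 cells (Homo sapiens) for cytotoxicity, read by MTT assay, with a stated time of 72 h; a higher number here means a weaker inhibitor, a lower number a stronger inhibitor. Going by the values given here, compound 2 (`COc1ccc(/C=C/C(=O)Nc2cc3c(Nc4ccc(F)c(Cl)c4)ncnc3cc2O[C@H]2CCOC2)c(OC)c1OC`), which bears a 2,3,4-trimethoxyphenyl group, gives 70 nM, the only number available. Compound 1 (`N#Cc1ccc(/C=C/C(=O)Nc2cc3c(Nc4ccc(F)c(Cl)c4)ncnc3cc2O[C@H]2CCOC2)cc1`), whose ring carries a nitrile instead, gives "not active" (no number reported), with no number reported. Compound 3 (`O=C(/C=C/c1ccccc1[N+](=O)[O-])Nc1cc2c(Nc3ccc(F)c(Cl)c3)ncnc2cc1O[C@H]1CCOC1`) has not yet been measured. It departs from compound 2 in one place: 2-nitrophenyl in place of 2,3,4-trimethoxyphenyl on a double-bonded chain carbon bound to a double-bonded chain carbon. Among the compounds with values here, no measured step exists to size this change. Within the data shown here, the only guide is compound 1, which also lacks the methoxy groups and gives "not active" (no number reported), so a loss of potency beyond the scatter is expected, though a single compound is thin support. The expected change is a 13-fold higher number from compound 2 to compound 3 (1.11 log units; beyond the scatter), towards weaker inhibition. In this assay, the estimated value for compound 3 is 900 nM, with an expected range from 120 nM to 7000 nM.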

Compound 3, half-maximal inhibitory concentration: 8820 nM
Beside the measured number, compound 3's estimate is 9.8-fold (0.99 log units) below it, and the stated range ends below it.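

In this assay, going by these compounds alone, exchanging 2,3,4-trimethoxyphenyl for 2-nitrophenyl gives a 130-fold higher number from compound 2 to compound 3 (2.10 log units; beyond the scatter), so this position now has a sized step, and a large one, where earlier there was only a single number. Compound 3 gives 8820 nM while compound 1 gives "not active" (no number reported), so these two rings without methoxy groups do not read alike. Nothing measured here accounts for the size of the step.

On these data alone, it remains open whether the potency of compound 2 needs all of its methoxy groups, or whether a ring with a single methoxy group would keep it. As far as these compounds go, it is equally open where a plain phenyl ring, or a ring bearing an amine or a carboxylic acid, would fall relative to compound 2 and compound 3.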